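This account rests on a few compounds, and the source may have more. Where it says the series, first, only, none or still open, it means among the compounds named here.

In a functional assay on HEL cells (Homo sapiens), read by microscopy (a higher number here means that more compound is tolerated, a lower number that less compound is tolerated), compound 1 `CCCCCCCC#Cc1cc2cn(COCCO)c(=O)nc2o1` gives 200000 nM. Compound 2 `CCCCCCCCC#Cc1cc2cn(COCCO)c(=O)nc2o1` is reported only as a limit of the assay, >= 20000 nM. The change between them, (methyl in place of hydrogen on a saturated chain carbon, seven bonds along the chain from a triple-bonded carbon), therefore yields a step that the limit leaves unreadable from compound 1 to compound 2. Compound 3 `CCCCCc1cc2cn(COCCO)c(O)nc-2n1` carries a different core; how the two cores differ is not broken down here. Compound 3 likewise reaches only a limit of the assay, > 400000 nM. Compound 4 `CCCCCCc1cc2cn(COCCO)c(O)nc-2n1` differs from compound 3 by methyl in place of hydrogen on a saturated chain carbon, five bonds along the chain from an aromatic carbon; this is the same kind of change as that between compound 1 and compound 2, but here the methyl stands five bonds along the chain from an aromatic carbon rather than seven bonds along the chain from a triple-bonded carbon. Because the earlier step is left unreadable by the limit of >= 20000 nM in this assay, at which 1 of the 3 values shown sits, and compound 3 itself sits at the limit of > 400000 nM in this assay, at which 1 of the 3 values shown sits, the step is expected to be a number no higher from compound 3 to compound 4 (the limit leaves the size open). Compound 4 is thus estimated at 400000 nM.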

Compound 4, minimum cytotoxic concentration: > 400000 nM
Compound 4: a limit, no number; the forecaster's own chance of this, stated with the estimate: 70%; the middle value sits exactly at the limit.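

Compound 3 and compound 4 each reach only a limit in this assay, and the step between them cannot be read. The compounds shown leave open at what concentration either compound becomes cytotoxic.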